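The compounds below may be only part of what the source reports. "The series", "measured", "known", "first", "only" and "open" are said of these compounds alone.

Series notes. For the measured compounds named here, compound 1 `ClCc1cccc(Cn2cnc3c(Cl)nc(Cl)nc32)c1` is the one member with a number in a functional assay on LOX IMVI cells (Homo sapiens) for cytotoxicity, read by sulforhodamine B assay, with a stated time of 48 h; on this read-out higher numbers stand for lower toxicity in this test and lower numbers for higher toxicity in this test; compound 1 gives 6910 nM. Compound 2 `Nc1nc(Cl)c2ncn(Cc3ccccc3CCl)c2n1` returns only a limit in this assay, > 100000 nM. Compound 3 `Nc1nc(Cl)c2ncn(Cc3ccc(CCl)cc3)c2n1` likewise returns only a limit in this assay, > 100000 nM. Compound 2 therefore stands at the limit of > 100000 nM in this assay, at which 2 of the 3 values shown sit, without a number of its own. Compound 4 `ClCc1ccccc1Cn1cnc2c(Cl)nc(Cl)nc21` is not yet measured in this assay. It differs from compound 2 in one place: chloro in place of amino on an aromatic carbon. Compound 1 carries chloro at that same place on the shared core and gives a number, 6910 nM, so a large step toward higher toxicity is expected, an at least 11-fold lower number from compound 2 to compound 4 (1.04 log units; beyond the scatter). Compound 4 is accordingly estimated at about 9000 nM, within 3000 nM to 40000 nM.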

Compound 4, concentration lethal to 50% of the cells: 850 nM
Estimate against measurement, compound 4: 11-fold (1.02 log units) above, outside the stated range (below it).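

In this assay, for the compounds shown here, chloro in place of amino on this aromatic carbon, between two ring nitrogen atoms, gives an at least 110-fold lower number from compound 2 to compound 4 (2.07 log units; beyond the scatter), the first direct reading of this change in a single matched pair. The step is a minimum, and its true size cannot be read, since compound 2 has only a limit: the limit of > 100000 nM in this assay, at which 2 of the 4 values shown sit.

On these data alone, whether the same change carries over to compound 3 remains open. So does the outcome with other groups at this place, such as methoxy, methylamino or a plain hydrogen.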